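The compounds below may be only part of what the source reports. "The series", "measured", "known", "first", "only" and "open" are said of these compounds alone.

Working notes on the series.

Compound 1 `O=C(CSc1nnc(-c2ccncc2)o1)N/N=C/c1ccc([N+](=O)[O-])cc1` is the reference point: in a functional assay on BGC-823 cells (Homo sapiens) for cytotoxicity, read by MTT assay, with a stated time of 48 h (a higher number here means a weaker inhibitor, a lower number a stronger inhibitor), compound 1 gives 31500 nM. Compound 2 `O=C(CSc1nnc(-c2ccncc2)o1)N/N=C/c1ccccc1[N+](=O)[O-]` carries the same core and in this assay compound 2 gives 41600 nM. Among the compounds with values here, the one measured step, a 1.3-fold higher number from compound 1 to compound 2 (0.12 log units; within the scatter), moves the nitro group around the ring without a change that stands out of the scatter. On the two numbers shown, compound 2 therefore cannot be separated from compound 1; the pair reads as one level.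

Compound 3 `O=C(CSc1nnc(-c2ccncc2)o1)N/N=C/c1cc(Cl)ccc1O` is the next member. It differs from compound 2 by 5-chloro-2-hydroxyphenyl in place of 2-nitrophenyl on a carbon with a double bond to nitrogen. Within the data shown here, no measured step exchanges a nitro group for a hydroxyl and a chlorine, so the only step that bears on this change is a 1.3-fold higher number from compound 1 to compound 2 (0.12 log units; within the scatter), which shows that altering the substitution of the aryl ring on the imine carbon left the number within the scatter. On that basis a step of about a 1.4-fold lower number from compound 2 to compound 3 (0.14 log units; within the scatter) is expected for compound 3, with no clear direction beyond the scatter. Compound 3 is estimated at 30000 nM, with a range from 9000 nM to 100000 nM.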

Compound 3, half-maximal inhibitory concentration: 5470 nM
Compound 3: the middle estimate sits 5.5-fold (0.74 log units) above what was measured; the whole stated range lies above it.
By their numbers in this assay, from the lowest: compound 3; then compounds 1 and 2 (each within the scatter of the next).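

At the carbon with a double bond to nitrogen, the aryl group can move the number beyond the scatter in this assay: 5-chloro-2-hydroxyphenyl in place of 2-nitrophenyl gives a modest step (a 7.6-fold lower number from compound 2 to compound 3 (0.88 log units; beyond the scatter)), and in place of 4-nitrophenyl it gives a similar one (a 5.8-fold lower number from compound 1 to compound 3 (0.76 log units; beyond the scatter)). The two nitrophenyl compounds alone had shown no response at this position, so compound 3 is the first sign in the series that the position is not flat, and the shift appears from either nitrophenyl compound. The change removes the nitro group and brings in a hydroxyl and a chlorine at once, so the step belongs to the exchange as a whole, and nothing at hand explains it.

The compounds shown leave open whether the hydroxyl, the chlorine, the pair or the loss of the nitro group carries the step. An unsubstituted phenyl, a chlorophenyl, a hydroxyphenyl, or a methoxy group in place of the hydroxyl on the same ring would begin to separate these contributions.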